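Bromo for Fluoro on the Sulfonyl Aryl Ring

The compounds below may be only part of what the source reports. "The series", "measured", "known", "first", "only" and "open" are said of these compounds alone.

Compound 1, `CC1=NC(c2cn(S(=O)(=O)c3ccccc3)c3ccc(C)cc23)CN1`: 17000 nM
Compound 2, `CC1=NC(c2cn(S(=O)(=O)c3ccc(F)cc3)c3ccc(C)cc23)CN1`: 9400 nM
Compound 3, `CC1=NC(c2cn(S(=O)(=O)c3ccccc3F)c3ccc(C)cc23)CN1`: 4100 nM

In an assay on isolated protein for inhibition of kallikrein-7 (Homo sapiens), read by fluorescence, with stated times of 10 min and 30 min (on this read-out lower numbers stand for stronger inhibition and higher numbers for weaker inhibition), compound 3 gives 4100 nM, the lowest of the three numbers; the distances are a 2.3-fold lower number from compound 2 to compound 3 (0.36 log units; beyond the scatter) and a 4.1-fold lower number from compound 1 to compound 3 (0.62 log units; beyond the scatter). Compound 4, `CC1=NC(c2cn(S(=O)(=O)c3ccccc3Br)c3ccc(C)cc23)CN1`, differs from it by bromo in place of fluoro on an aromatic carbon. Among the compounds with values here, no measured step exchanges one halogen for another: a 1.8-fold lower number from compound 1 to compound 2 (0.26 log units; within the scatter) and a 4.1-fold lower number from compound 1 to compound 3 (0.62 log units; beyond the scatter) each place fluoro where hydrogen stood, and a 2.3-fold lower number from compound 2 to compound 3 (0.36 log units; beyond the scatter) changes where the fluoro sits. These steps show that a single change on this ring can move the number beyond the scatter, but they give no direction for bromo. The step from compound 3 to compound 4 is therefore expected to be small, a 1.4-fold lower number from compound 3 to compound 4 (0.14 log units; within the scatter). Compound 4 is estimated at 3000 nM, within a range from 900 nM to 10000 nM.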

Compound 4, half-maximal inhibitory concentration: 390 nM
The estimate for compound 4 lay 7.7-fold (0.89 log units) above the measured number; measured number below the stated range.
By their numbers in this assay, from the lowest: compound 4; then compound 3; then compounds 2 and 1 (each within the scatter of the next).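

In this assay, within the data shown here, the choice of halogen at this place proves decisive: an 11-fold lower number from compound 3 to compound 4 (1.02 log units; beyond the scatter) exceeds every step among the earlier compounds, which showed only what fluoro could do on this ring. Bromo ortho to a large group also gives a 24-fold lower number from compound 2 to compound 4 (1.38 log units; beyond the scatter) and a 44-fold lower number from compound 1 to compound 4 (1.64 log units; beyond the scatter), both large. Nothing available accounts for these steps.

As far as these compounds go, whether chloro, iodo or methyl at the same place would match bromo remains open, as does whether the size of the step depends on the rest of the core.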